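The compounds below may be only part of what the source reports. "The series", "measured", "known", "first", "only" and "open" are said of these compounds alone.

Compound 1, `C=C(Br)C(=O)Nc1cccc(-c2cn3nc(CCc4ccccc4)sc3n2)c1`, carries a bromoacrylamide on a phenyl ring that is joined to a fused bicyclic core bearing a phenethyl group. In a functional assay on CCRF-CEM cells (Homo sapiens) for inhibition, read by cell counting, with a stated time of 3 days (on this read-out higher numbers stand for weaker inhibition and lower numbers for stronger inhibition), compound 1 gives 4200 nM, the lowest of the three numbers in hand. Compound 3, `Cc1ccc(-c2nn3cc(-c4cccc(N)c4)nc3s2)cc1`, gives 5900 nM in this assay, a number that sits within the scatter of compound 1, so no order between the two can be claimed. Compound 2, `Nc1cccc(-c2cn3c(-c4ccccc4)csc3n2)c1`, gives 29000 nM in this assay, which lies beyond the scatter above compound 1. No pair among these three differs in one place only, so no single step is available to guide a prediction.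

Compound 4, `C=C(Br)C(=O)Nc1cccc(-c2cn3nc(-c4ccc(CC)cc4)sc3n2)c1`, differs from compound 1 in the group on the core: 4-ethylphenyl in place of phenethyl on an aromatic carbon. Within the data shown here, with no matching step among the measured compounds, and compound 3 showing that a directly attached aryl group on a related core gives 5900 nM, the expected step from compound 1 to compound 4 is a 1.2-fold lower number from compound 1 to compound 4 (0.08 log units; within the scatter), small and not beyond the scatter in either direction. Compound 4 is therefore estimated at 3500 nM in this assay, with a range from 1200 nM to 10000 nM.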

Compound 4, half-maximal inhibitory concentration: 3400 nM
Beside the measured number, compound 4's estimate is 1.0-fold (0.01 log units) above it; low and high end bracket the measured number.
By their numbers in this assay, from the lowest: compounds 4, 1 and 3 (each within the scatter of the next); then compound 2.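

In this assay, 4-ethylphenyl in place of phenethyl gives a 1.2-fold lower number from compound 1 to compound 4 (0.09 log units; within the scatter), the first step shown that changes one place only. At this position on the shared core, the carbon-only aromatic ring can therefore be held on a chain, as in compound 1, or attached directly with the ethyl group carried on it, as in compound 4, with no difference that this read-out can separate. No measurement shown offers a reason for this result.

The two groups have the same atoms and each holds a six-membered aromatic ring, so the step says nothing about a group without such a ring at this position, such as a carboxylic acid or a morpholine. It also leaves open what the bromoacrylamide contributes, since a plain acrylamide on the same phenyl ring does not appear among these compounds.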